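Three limits and one untested group swap

This account rests on a few compounds, and the source may have more. Where it says the series, first, only, none or still open, it means among the compounds named here.

In an ADME assay on HCT-116 cells (Homo sapiens) for cytotoxicity, read by CellTiter-Glo, with a stated time of 72 h (on this read-out lower numbers stand for stronger inhibition and higher numbers for weaker inhibition), compound 1 `Cc1cc(C)c(S(=O)(=O)N2CCC(N3CCC(C)CC3)CC2)c(C)c1` gives > 5000 nM, which is a limit and not a number. Compound 2 `Cc1ccc(-c2ccccc2S(=O)(=O)N2CCC(N3CCC(C)CC3)CC2)cc1` gives > 5000 nM, also a limit. Compound 3 `Cc1c(C)c(S(=O)(=O)N2CCC(N3CCC(C)CC3)CC2)c(C)c2c1OC(C)(C)C2` gives > 10000 nM, again a limit. Among the compounds with values here, compound 1 therefore stands at the limit of > 5000 nM in this assay, at which 2 of the 3 values shown sit, and no measured step between compounds is available as a guide.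

Compound 4 `Cc1ccc(C2CCN(S(=O)(=O)c3c(C)cc(C)cc3C)CC2)cc1` has 4-methylphenyl in place of 4-methylpiperidin-1-yl on a saturated ring carbon. The limit of compound 1, > 5000 nM, is the only anchor, so no step beyond the scatter is expected in this assay, in either direction. The expected change is small: a step that the limit leaves unreadable from compound 1 to compound 4. Compound 4 is estimated at about 7000 nM, with an expected range of 2500 nM to 20000 nM.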

Compound 4, half-maximal inhibitory concentration: > 5000 nM
Compound 4 was reported as a limit; the forecaster's own chance of this, stated with the estimate: 85%; the middle value does not contradict the limit.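

No step can be read from compound 1 to compound 4, as both are reported only as limits: the limit of > 5000 nM in this assay, at which 3 of the 4 values shown sit.

The compounds shown leave open what concentration, if any, gives half-maximal inhibition in this assay.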